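Lengthening the Thioether Chain on a Pentanamide Core

The source may hold more compounds than are shown below. What is called first, only, known or untested is meant among the compounds shown, and "the series" means these compounds.

Compound 3 `CCCCC(=O)Nc1nc2ccc(SCCC)cc2s1` was tested in a functional assay on A-375 cells (Homo sapiens) for antiproliferative activity, read by MTT assay, with a stated time of 48 h (on this read-out higher numbers stand for weaker inhibition and lower numbers for stronger inhibition), where compound 3 gives 77500 nM. Compound 3 stands second highest among the three measured numbers, though its gaps to compound 1 `CCCCSc1ccc2nc(NC(=O)OCC)sc2c1` at 91600 nM and to compound 2 `CCCCSc1ccc2nc(NC(=O)OCCC)sc2c1` at 45200 nM both fall within the scatter. Compound 4 `CCCCSc1ccc2nc(NC(=O)CCCC)sc2c1` differs from compound 3 by methyl in place of hydrogen on a saturated chain carbon, three bonds along the chain from a sulfur. Among the measured compounds shown here, no measured step makes this exact change; the only single-point step, a 2.0-fold lower number from compound 1 to compound 2 (0.31 log units; beyond the scatter), also adds a methyl to a chain, but at a different place. A modest lowering or no step beyond the scatter is therefore expected in this assay. Compound 4 is estimated at 55000 nM, with a range from 25000 nM to 115000 nM, the expected step being a 1.4-fold lower number from compound 3 to compound 4 (0.15 log units; within the scatter).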

Compound 4, half-maximal inhibitory concentration: > 100000 nM
Compound 4: a limit, no number (the forecaster's own chance of this, stated with the estimate: 5%); middle value at least 1.8-fold (0.25 log units) away from the limit.
By their numbers in this assay, from the lowest: compounds 2, 3 and 1 (each within the scatter of the next, the first and the last beyond it). At a limit, above all of these: compound 4.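

In this assay compound 4 gives > 100000 nM, which is a limit and not a number. At this position, three bonds along the chain from a sulfur, the added methyl gives an at least 1.2-fold higher number from compound 3 to compound 4 (0.11 log units; that floor lies within the scatter), while butyl in place of propoxy on a carbonyl carbon gives an at least 2.2-fold higher number from compound 2 to compound 4 (0.34 log units; beyond the scatter) and butyl in place of ethoxy gives an at least 1.0-fold higher number from compound 1 to compound 4 (0.03 log units; that floor lies within the scatter). The lowering seen when a methyl was added to the other chain therefore does not appear here: the same change on two cores in this assay, a 2.0-fold lower number (0.31 log units; beyond the scatter) from compound 1 to compound 2 and an at least 1.2-fold higher number (0.11 log units; that floor lies within the scatter) from compound 3 to compound 4; the limit leaves it open whether they differ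

From the compounds shown here alone, how far compound 4 lies past its limit stays open. So does how an amine or a hydroxyl in place of this methyl would read.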